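A few compounds are considered here, and "the series" means these few. Any claim that something is new, unique, unknown or untested is made for them only; others in the source may bear on it.

Compounds measured in a functional assay on A549 cells (Homo sapiens) for cytotoxicity, read by WST assay, with a stated time of 48 h; a lower number here means a stronger inhibitor, a higher number a weaker inhibitor:

- compound 1 `COc1ccc2c(/C=C(\C#N)C(=O)c3c[nH]c4cc(OC)ccc34)c[nH]c2c1`: 1700 nM
- compound 2 `COc1ccc2c(/C=C(\C#N)C(=O)c3c[nH]c4ccccc34)c[nH]c2c1`: 5800 nM
- compound 3 `COc1ccc2[nH]cc(/C=C(\C#N)C(=O)c3c[nH]c4cc(F)ccc34)c2c1`: 26300 nM

Among these three, compound 1 holds the lowest number and is therefore the strongest inhibitor of the set. The next compound to be tested is compound 4 `COc1ccc2c(C(=O)/C(C#N)=C/c3c[nH]c4cc(F)ccc34)c[nH]c2c1`, which keeps the core of compound 1 but carries fluoro in place of methoxy on an aromatic carbon.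

Within the data shown here, only one measured step bears on this change. Losing a methoxy group for hydrogen gave a 3.4-fold higher number from compound 1 to compound 2 (0.53 log units; beyond the scatter), a modest change. That step removes the second methoxy group of compound 1, not the one exchanged here, so it serves only as a guide by analogy. Among the measured compounds shown here, compound 3 also carries a fluoro group and reads 26300 nM, but it differs from compound 1 in more than one place, so no single step can be drawn from it.

A modest loss of similar size therefore seems the likeliest outcome in this assay. The expected step is a 3.5-fold higher number from compound 1 to compound 4 (0.55 log units; beyond the scatter). For compound 4 the estimated value is 6000 nM, with an expected range from 2000 nM to 20000 nM.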

Compound 4, half-maximal inhibitory concentration: 800 nM
Beside the measured number, compound 4's estimate is 7.5-fold (0.88 log units) above it; the measured number lies below the stated range.
By their numbers in this assay, from the lowest: compound 4; then compound 1; then compound 2; then compound 3.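

In this assay, putting fluoro in place of methoxy on this aromatic carbon gives a 2.1-fold lower number from compound 1 to compound 4 (0.33 log units; beyond the scatter) and thus a modest gain, so the methoxy group at this place is not needed for the activity of compound 1, and a single fluorine atom can stand in its place without loss. Among these compounds, this runs the opposite way to the only earlier single change, a 3.4-fold higher number from compound 1 to compound 2 (0.53 log units; beyond the scatter) where the other methoxy group gave way to hydrogen, so the two methoxy groups of compound 1 cannot be treated as interchangeable, although the two steps differ in both the place and the incoming group. Nothing measured here accounts for the direction of the new step.

The compounds shown leave open whether the gain belongs to fluoro itself or would also follow from plain hydrogen at this place, since that one-place comparison is absent from the set. They also leave open how a chloro group, a hydroxyl group or an amine on the same aromatic carbon would read in this assay.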